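Benzofuran in place of furan on a nucleoside core

The compounds below may be only part of what the source reports. "The series", "measured", "known", "first", "only" and "open" are said of these compounds alone.

Compound 1 `O=c1[nH]cnc2c1c(-c1ccoc1)cn2[C@@H]1O[C@H](CO)[C@@H](O)[C@H]1O` gives a limit of the assay, > 100000 nM.
Compound 2 `Cc1nc(N)c2c(-c3ccoc3)cn([C@@H]3O[C@H](CO)[C@@H](O)[C@H]3O)c2n1` gives a limit of the assay, > 100000 nM.
Compound 3 `O=c1[nH]cnc2c1c(-c1cc3ccccc3o1)cn2[C@@H]1O[C@H](CO)[C@@H](O)[C@H]1O` gives 62700 nM.

In an ADME assay on BJ cells (Homo sapiens), read by MTT assay, with a stated time of 72 h (a higher number here means a weaker inhibitor, a lower number a stronger inhibitor), compound 1 reaches only a limit. Compound 2 likewise reaches only a limit. How the core of compound 1 differs from that of compound 2 is not broken down here. Compound 3 carries the change 1-benzofuran-2-yl in place of furan-3-yl on an aromatic carbon and shows the step of an at least 1.5-fold lower number from compound 1 to compound 3 (0.20 log units; that floor lies within the scatter), whose floor is set by the limit of > 100000 nM in this assay, at which 2 of the 3 values shown sit. The same change, (1-benzofuran-2-yl in place of furan-3-yl on an aromatic carbon), leads from compound 2 to compound 4 `Cc1nc(N)c2c(-c3cc4ccccc4o3)cn([C@@H]3O[C@H](CO)[C@@H](O)[C@H]3O)c2n1`; the two places are identical word for word. Compound 4 is expected to give 70000 nM, between 30000 nM and 150000 nM. The expected step of an at least 1.4-fold lower number from compound 2 to compound 4 (0.15 log units; that floor lies within the scatter) rests on the measured step of an at least 1.5-fold lower number from compound 1 to compound 3 (0.20 log units; that floor lies within the scatter) and allows that compound 4 may again sit at the limit.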

Compound 4, half-maximal inhibitory concentration: > 100000 nM
Compound 4: only a limit was reported; the forecaster's own chance of this, stated with the estimate: 45%; at least 1.4-fold (0.15 log units) between middle value and limit.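

Compound 2 and compound 4 both sit at a limit of this assay, so the step between them cannot be read. The compounds shown leave open whether 1-benzofuran-2-yl in place of furan-3-yl changes the number on the core of compound 2 at all.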